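The source may hold more compounds than are shown below. What is called first, only, known or untested is meant among the compounds shown, and "the series" means these compounds.

Three compounds carry a measurement in a functional assay on CHO-K1 cells for antagonist activity at C-X-C chemokine receptor type 3 (Homo sapiens), read by FLIPR, with a stated time of 10 min; a lower number here means a stronger inhibitor, a higher number a weaker inhibitor. Compound 1 `O=C(Nc1ncccc1N1CCN(C(=O)Cn2cnc3cccnc32)CC1)c1cccc(Cl)c1` gives 177 nM. Compound 2 `C[C@@H]1CN(c2sc(C3COC3)nc2-c2nc3ccccc3[nH]2)CCN1C(=O)Cn1cnc2cccnc21` gives 53 nM. Compound 3 `CCOc1ncc(-c2nc(C(F)(F)F)sc2N2CCN(C(=O)Cn3cnc4ccccc43)[C@H](C)C2)cn1` gives 2 nM, the lowest of the three numbers; its gap to compound 2, the nearest, and its gap to compound 1, the furthest, both lie beyond the scatter, so compound 3 stands as the strongest inhibitor of the three in this assay.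

Compound 4 `CCOc1ncc(-c2nc(C(F)(F)F)sc2N2CCN(C(=O)Cn3cc(Cl)cn3)[C@H](C)C2)cn1` is not yet measured. It differs from compound 3 in one place: 4-chloro-1H-pyrazol-1-yl in place of 1H-benzimidazol-1-yl on a saturated chain carbon bound to a carbonyl carbon. Going by the values given here, no pair of measured compounds shows this change, so the size of the step rests on expectation alone. The step of a 4.0-fold higher number from compound 3 to compound 4 (0.60 log units; beyond the scatter) is expected to be modest but beyond the scatter, in the direction of a weaker inhibitor. For compound 4 the estimate in this assay is 8 nM, with a range from 2 nM to 40 nM.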

Compound 4, half-maximal inhibitory concentration: 5.1 nM
Estimate against measurement, compound 4: 1.6-fold (0.20 log units) above, and the stated range covers the measured number.
By their numbers in this assay, from the lowest: compound 3; then compound 4; then compound 2; then compound 1.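

In this assay, the change of 1H-benzimidazol-1-yl to 4-chloro-1H-pyrazol-1-yl on a saturated chain carbon bound to a carbonyl carbon gives a 2.6-fold higher number from compound 3 to compound 4 (0.41 log units; beyond the scatter), a modest step but one beyond the scatter. The six-membered aromatic ring of carbon only is therefore not needed for a low number at this position, since compound 4, with one five-membered aromatic ring and chlorine, still reads 5.1 nM. Nothing available accounts for the size of this step.

From the compounds shown here alone, this single pair cannot separate the loss of the six-membered ring from the arrival of the chlorine, so the effect of 1H-pyrazol-1-yl alone, or of a methyl or nitrile in place of the chlorine, stays open. Going by these compounds, whether the same change holds on the cores of compound 1 and compound 2 also remains unknown.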